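Alkoxy versus pyrazolyl on the shared core: mouse microsomal clearance

A few compounds are considered here, and "the series" means these few. Any claim that something is new, unique, unknown or untested is made for them only; others in the source may bear on it.

Compound 1 `Cc1cc(OC(C)C)cc(C(=O)NNS(=O)(=O)c2ccccc2F)c1`: in an ADME assay on microsomes from liver (Mus musculus) for metabolic stability, read by HPLC, using NADPH, with a stated time of 60 min, tested at 1 uM, in the presence of a further agent that is not named here (on this read-out higher numbers stand for fast clearance and lower numbers for slow clearance), compound 1 gives > 866 uL/min, which is a limit of the assay and not a number.
Compound 2 `Cc1cc(C(=O)NNS(=O)(=O)c2ccccc2F)cc(-n2cc(F)cn2)c1`: in this assay compound 2 gives 464 uL/min.

Compound 2 carries the only number shown; the other entry, for compound 1, is a limit. Compound 1 sits at the limit of > 866 uL/min in this assay, at which 1 of the 2 values shown sits.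

The next compound, compound 3 `CCOc1cc(C)cc(C(=O)NNS(=O)(=O)c2ccccc2F)c1`, differs from compound 2 in one place: ethoxy in place of 4-fluoro-1H-pyrazol-1-yl on an aromatic carbon.

Among the compounds with values here, one measured step bears on this change, and it runs the other way: an at least 1.8-fold lower number from compound 1 to compound 2 (0.27 log units; that floor lies within the scatter), a step whose floor lies within the scatter. Replacing the pyrazolyl group of compound 2 with an ethoxy group, a chain close in kind to the isopropoxy group of compound 1, is read as undoing that step. A rise in the number is therefore expected, of a size near the measured step, and the value may again reach the limit.

Compound 3 is expected to give 800 uL/min, within a range from 400 uL/min to 1600 uL/min. The expected step is a 1.7-fold higher number from compound 2 to compound 3 (0.24 log units; within the scatter).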

Compound 3, intrinsic clearance in a liver preparation (reported as CLH), per the amount of preparation that the assay uses: > 866 uL/min
Compound 3 was reported as a limit; the forecaster's own chance of this, stated with the estimate: 40%; middle value at least 1.0-fold (0.03 log units) away from the limit.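

In this assay compound 3 gives > 866 uL/min, which is a limit of the assay and not a number. From the compounds shown here alone, with ethoxy in place of 4-fluoro-1H-pyrazol-1-yl the series shows an at least 1.8-fold higher number from compound 2 to compound 3 (0.27 log units; that floor lies within the scatter), so a second alkoxy group, and not only the isopropoxy group of compound 1, gives a result that differs from the pyrazolyl compound in the same direction, though the size of the step stays open. The step between compound 1 and compound 3 cannot be read, and the two alkoxy compounds now share the ceiling of the read-out: the limit of > 866 uL/min in this assay, at which 2 of the 3 values shown sit.

Going by these compounds, how far compound 1 and compound 3 lie past that limit remains open, so the two alkoxy chains cannot be ordered and the full size of the change from the pyrazolyl group is unknown. Also open, on these data alone, is whether a different group on this aromatic carbon, such as an amine or a nitrile, would give a number inside the range of the assay, or a lower one than compound 2 at 464 uL/min.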